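Methoxy for fluoro on the benzothiazole of compound 2

The source may hold more compounds than are shown below. What is called first, only, known or untested is meant among the compounds shown, and "the series" means these compounds.

Compound 1 `O=C(Nc1nc2ccc(F)cc2s1)c1cc(-c2ccc(F)cc2)n2nc(-c3ccccc3)cc2n1`: 14800 nM
Compound 2 `COc1cc(-c2cc(C(=O)Nc3nc4ccc(F)cc4s3)nc3cc(-c4ccccc4)nn23)cc(OC)c1OC`: 22400 nM

In a functional assay on A549 cells (Homo sapiens) for cytotoxicity, read by MTT assay, with a stated time of 48 h (a lower number here means a stronger inhibitor, a higher number a weaker inhibitor), compound 2 gives the highest of the two numbers measured; its nearest neighbour is compound 1, and a 1.5-fold higher number from compound 1 to compound 2 (0.18 log units; within the scatter), a change of 3,4,5-trimethoxyphenyl for 4-fluorophenyl. Compound 3 `COc1ccc2nc(NC(=O)c3cc(-c4cc(OC)c(OC)c(OC)c4)n4nc(-c5ccccc5)cc4n3)sc2c1` differs from compound 2 by methoxy in place of fluoro on an aromatic carbon. Among the measured compounds shown here, no measured step touches this position, so no direction beyond the scatter is expected for a 1.1-fold lower number from compound 2 to compound 3 (0.05 log units; within the scatter). Compound 3 is therefore estimated at 20000 nM, within 8000 nM to 50000 nM.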

Compound 3, half-maximal inhibitory concentration: 2810 nM
For compound 3 the middle estimate is 7.1-fold (0.85 log units) above the measured one; the whole stated range lies above it.
By their numbers in this assay, from the lowest: compound 3; then compounds 1 and 2 (each within the scatter of the next).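

In this assay, replacing fluoro with methoxy on this aromatic carbon gives an 8.0-fold lower number from compound 2 to compound 3 (0.90 log units; beyond the scatter), a change beyond the scatter. The earlier step, on the other aryl group, stayed within the scatter, so this is the first position shown where a single change moves the number beyond it. Nothing available accounts for the gain. As far as these compounds go, whether methoxy has the same effect alongside the 4-fluorophenyl group of compound 1 remains open, as does how an amine or an ethoxy group would behave on this carbon.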